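This account rests on a few compounds, and the source may have more. Where it says the series, first, only, none or still open, it means among the compounds named here.

Measured so far in a functional assay on DU-145 cells (Homo sapiens) for cytotoxicity, read by MTT assay, with a stated time of 48 h; a higher number here means a weaker inhibitor, a lower number a stronger inhibitor:
compound 1 `CCOC(=O)c1c(-c2cc3ccccc3oc2=O)nn(-c2ccccc2)c1C(=O)OCC` gives 57000 nM
compound 2 `CCOC(=O)c1c(-c2cc3ccccc3oc2=O)nn(-c2ccc(OC)cc2)c1C(=O)OCC` gives 39000 nM
compound 3 `CCOC(=O)c1c(-c2cc3ccccc3oc2=O)nn(-c2cccc(Cl)c2)c1C(=O)OCC` gives 35000 nM

Compound 3 holds the lowest of the three numbers as written, yet its steps to the others, a 1.1-fold lower number from compound 2 to compound 3 (0.05 log units; within the scatter) and a 1.6-fold lower number from compound 1 to compound 3 (0.21 log units; within the scatter), both lie within the scatter, so no ordering of the three is established. Compound 4 `CCOC(=O)c1c(-c2cc3ccccc3oc2=O)nn(-c2ccc(Cl)cc2)c1C(=O)OCC` differs from compound 3 by 4-chlorophenyl in place of 3-chlorophenyl on an aromatic nitrogen. Within the data shown here, no measured pair covers this exact change; the nearest guides are the other substituent changes on the same ring, a 1.5-fold lower number from compound 1 to compound 2 (0.16 log units; within the scatter), a 1.6-fold lower number from compound 1 to compound 3 (0.21 log units; within the scatter) and a 1.1-fold lower number from compound 2 to compound 3 (0.05 log units; within the scatter), each within the scatter. No step beyond the scatter is therefore expected in this assay in either direction. Compound 4 is expected near 35000 nM, between 17000 nM and 70000 nM. That expectation amounts to no change at the digits printed from compound 3 to compound 4 (within the scatter).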

Compound 4, half-maximal inhibitory concentration: 26000 nM
Beside the measured number, compound 4's estimate is 1.3-fold (0.13 log units) above it; low and high end bracket the measured number.
By their numbers in this assay, from the lowest: compounds 4, 3, 2 and 1 (each within the scatter of the next, the first and the last beyond it).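

In this assay, among these compounds, a 2.2-fold lower number from compound 1 to compound 4 (0.34 log units; beyond the scatter) is the first step beyond the scatter, so 4-chlorophenyl on the aromatic nitrogen separates modestly from plain phenyl, which neither 3-chlorophenyl nor 4-methoxyphenyl did. Compound 4 remains unresolved from both of those compounds, with a 1.3-fold lower number from compound 3 to compound 4 (0.13 log units; within the scatter) and a 1.5-fold lower number from compound 2 to compound 4 (0.18 log units; within the scatter), so the position of the chloro group on this ring makes no readable difference here. No evidence on the origin of these steps is at hand.

The compounds shown leave open how an amine or a carboxylic acid on this phenyl ring would read in this assay. Also open, as far as these compounds go, is whether a longer chain in place of the ethoxycarbonyl groups would shift the number.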